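Series notes: aryl swap on the fused ring

The source may hold more compounds than are shown below. What is called first, only, known or untested is meant among the compounds shown, and "the series" means these compounds.

In a physicochemical assay for acid dissociation, compound 1 `c1ccc(CCc2ccc3c(NCCCNCc4ccco4)ccnc3c2)cc1` gives 9.47 and compound 2 `c1ccc(-c2ccc3c(NCCCNCc4ccco4)ccnc3c2)cc1` gives 9.47; compound 2 stands level with compound 1, its nearest neighbour. Among the compounds with values here, the only measured step bearing on the next change is no change at the digits printed from compound 1 to compound 2 (within the scatter). Compound 3 `c1coc(CNCCCNc2ccnc3cc(-c4cccc5ccccc45)ccc23)c1` differs from compound 2 by naphthalen-1-yl in place of phenyl on an aromatic carbon. Within the data shown here, with the one measured step at the same aromatic carbon showing no change, no step beyond the scatter is expected in this assay, so no change at the digits printed from compound 2 to compound 3 (within the scatter) is the expected size. Compound 3 is therefore estimated at 9.47 in this assay, with a range of 9.1 to 9.8.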

Compound 3, acid dissociation constant: 9.47
The estimate for compound 3 equals the measured number at the digits printed; the range from low to high includes it.
By their numbers in this assay, from the lowest: compounds 1, 2 and 3 (each within the scatter of the next).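

In this assay, naphthalen-1-yl in place of phenyl on this aromatic carbon gives no change at the digits printed from compound 2 to compound 3 (within the scatter), so a substituent with two six-membered aromatic rings reads the same as one with a single ring. Naphthalen-1-yl in place of phenethyl gives no change at the digits printed from compound 1 to compound 3 (within the scatter), so all three substituents shown at this carbon read alike. No evidence is available on why the reading holds across them. Substituents made only of carbon and hydrogen are all that is shown here, so whether an amine or a carboxylic acid at this aromatic carbon would shift the reading stays open.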